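The source may report more compounds than this note shows. Statements on the series, on what has been measured and on what is new or still open speak of the compounds shown alone.

Working notes on the series. Three compounds carry a measured value in a functional assay (aorta) with Oryctolagus cuniculus as the target; on this read-out lower numbers stand for stronger inhibition and higher numbers for weaker inhibition. Compound 1, `N#Cc1cccc(Cn2nc(-c3ccc(CO)o3)c3ccccc32)c1`, gives 26000 nM. Compound 2, `OCc1ccc(-c2nn(Cc3ccccc3F)c3ncncc23)o1`, gives 9400 nM. Compound 3, `CCCCc1cnc(-c2nn(Cc3ccccc3F)c3ncccc23)nc1N`, gives 218000 nM, the highest of the three numbers; its gap to compound 1 and its gap to compound 2 both lie beyond the scatter, so compound 3 stands as the weakest inhibitor of the three. For the measured compounds named here, the three compounds differ from one another in more than one place, so no single step between measured compounds can be read from them.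

Compound 4, `Nc1nc(-c2nn(Cc3ccccc3F)c3ncccc23)ncc1CC(F)(F)F`, is the next compound and is not yet measured. It differs from compound 3 in one place: trifluoromethyl in place of propyl on a saturated chain carbon bound to an aromatic carbon. Going by the values given here, no measured pair in the set shows a change of this kind, so the direction of the move in this assay cannot be taken from the data. The expectation is a modest move, within or just beyond the scatter, and no clear direction. For compound 4 the estimate in this assay is 150000 nM, with a range from 40000 nM to 500000 nM. The expected step is a 1.5-fold lower number from compound 3 to compound 4 (0.16 log units; within the scatter).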

Compound 4, half-maximal inhibitory concentration: 508000 nM
For compound 4 the middle estimate is 3.4-fold (0.53 log units) below the measured one, outside the stated range (above it).
By their numbers in this assay, from the lowest: compound 2; then compound 1; then compound 3; then compound 4.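

In this assay, the change from butyl to 2,2,2-trifluoroethyl gives a 2.3-fold higher number from compound 3 to compound 4 (0.37 log units; beyond the scatter), a modest step beyond the scatter and the first single-place comparison available in the series. At this position, trifluoromethyl in place of propyl on a saturated chain carbon bound to an aromatic carbon therefore moves the number towards weaker inhibition, and compound 4 now stands as the weakest inhibitor of the four compounds. No data at hand bear on the reason for this step.

Going by these compounds, only butyl and 2,2,2-trifluoroethyl are compared at this position, so it remains open how a shorter alkyl chain, a longer alkyl chain, an amine or a carboxylic acid would read there. On these data alone, whether the same change would give a step of similar direction and size on a different core also remains open.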